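Solubility notes: methoxy for methyl on the shared core

The compounds below may be only part of what the source reports. "The series", "measured", "known", "first", "only" and "open" are said of these compounds alone.

Compound 3 `Cc1ccc2c(NCc3ccco3)nc(NC(C)C)nc2c1` carries a methyl on the shared core. In a physicochemical assay for solubility, at pH 2 (a lower number here means a less soluble compound, a higher number a more soluble compound), compound 3 gives >= 30000 nM, which is a limit of the assay and not a number. Compound 1 `CC(C)Nc1nc(NCc2ccco2)c2ccccc2n1` likewise gives only a limit, >= 30000 nM. Compound 2 `CC(C)Nc1nc(NCc2ccco2)c2ccc(Cl)cc2n1` also sits at a limit, >= 30000 nM. Because all three values sit at the limit (the limit of >= 30000 nM in this assay, at which 3 of the 3 values shown sit), the steps a step that the two limits leave unreadable from compound 1 to compound 2, a step that the two limits leave unreadable from compound 1 to compound 3 and a step that the two limits leave unreadable from compound 2 to compound 3 cannot be read in size or direction. Compound 4 `COc1ccc2c(NCc3ccco3)nc(NC(C)C)nc2c1` differs from compound 3 by methoxy in place of methyl on an aromatic carbon. For the measured compounds named here, no measured step bears on that change, so no direction can be drawn from it. Compound 4 is therefore expected to remain at the limit, with a number no higher from compound 3 to compound 4 (the limit leaves the size open) estimated as no step beyond the scatter. The estimate for compound 4 is 30000 nM, range 15000 nM to 60000 nM.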

Compound 4, solubility: >= 30000 nM
Compound 4: a limit, no number; the forecaster's own chance of this, stated with the estimate: 75%; the middle value lies on the limit itself.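

Compound 4 joins compound 1, compound 2 and compound 3 in giving only a limit in this assay, so no step to compound 4 can be read: the limit of >= 30000 nM in this assay, at which 4 of the 4 values shown sit.

The compounds shown leave open whether hydrogen, chloro, methyl and methoxy on the shared core differ at all in this assay.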